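This account rests on a few compounds, and the source may have more. Where it says the series, first, only, none or still open, it means among the compounds named here.

In a functional assay on 3T3-L1 cells (Mus musculus) for inhibition, with a stated time of 20 min, tested at 20 uM (a higher number here means more inhibition at the concentration tested (going by the name of the read-out), a lower number less inhibition), two compounds have been measured so far. Compound 1, with the structure `Fc1cccc(CNCc2ccccc2)c1F`, is a small molecule; in this assay compound 1 gives -38.5%. Compound 2, with the structure `Cc1ccc(S(=O)(=O)N(Cc2cn(Cc3ccc(F)cc3F)nn2)Cc2cn(S(=O)(=O)c3ccc(C)cc3)c3ccccc23)cc1`, is far larger; in this assay compound 2 gives 12.3%. Of the two numbers, that of compound 2 is the higher, and compound 1 lies a long way under it, beyond the usual scatter, so the two are clearly different in this read-out.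

Compound 3, with the structure `Cc1ccc(S(=O)(=O)N(Cc2cn(Cc3cccc(F)c3F)nn2)Cc2cn(S(=O)(=O)c3ccc(C)cc3)c3ccccc23)cc1`, has the same atoms as compound 2 joined differently: 2,3-difluorophenyl in place of 2,4-difluorophenyl on a saturated chain carbon bound to an aromatic nitrogen. Within the data shown here, no pair of measured compounds differs in only one place, so no single-change step is available to guide the expectation. The rearrangement of two fluorines within one ring on the edge of a large molecule is expected to move the read-out little, and the step from compound 2 to compound 3 is estimated as a number 2.3 percentage points lower from compound 2 to compound 3 (within the scatter), which does not go beyond the scatter. For compound 3 in this assay the estimated value is 10%, with a range from -12% to 32%.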

Compound 3, a percentage reported as inhibition, at one concentration (the size of the read-out at that concentration, not a potency): 71.5%
For compound 3 the middle estimate is 61.5 percentage points below the measured one; the measured number lies above the stated range.
By their numbers in this assay, from the lowest: compound 1; then compound 2; then compound 3.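

In this assay, replacing 2,4-difluorophenyl with 2,3-difluorophenyl on a saturated chain carbon bound to an aromatic nitrogen gives a number 59.2 percentage points higher from compound 2 to compound 3 (beyond the scatter). Among these compounds, this is the first comparison here between compounds that differ in one place, and it shows that this position can matter greatly: the group that leaves and the group that enters have the same atoms and the same counts of hydrogen-bond donors and acceptors, yet rearranging the two fluorines alone separates the read-outs clearly. Nothing available here explains why this rearrangement has such a large effect on the read-out.

A single pair cannot show which fluorine placement matters most, or whether the result would hold for a plain phenyl ring, a 3-fluorophenyl group, or a ring carrying chlorine or methoxy at this position. Because the read-out comes from one concentration and is not a potency, the pair also leaves open how compound 3 would behave across a range of concentrations.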